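The source may hold more compounds than are shown below. What is called first, only, known or untested is meant among the compounds shown, and "the series" means these compounds.

Measured so far:
compound 1 `COc1cc(/C=N/Nc2nc(-c3ccccc3)cs2)c(Br)c(Br)c1OC` — 26500 nM
compound 2 `COc1cc(/C=N/Nc2nc(-c3ccccc3)cs2)cc(Br)c1OC` — 64200 nM
compound 3 `Fc1ccc(/C=N/Nc2nc(-c3ccc(F)c(F)c3)cs2)cc1F` — 14200 nM

In a functional assay on Caco-2 cells (Homo sapiens) for inhibition, read by MTT assay, with a stated time of 48 h (a higher number here means a weaker inhibitor, a lower number a stronger inhibitor), compound 1 gives 26500 nM, the second highest of the three numbers. Compound 3 gives 14200 nM, within the scatter of compound 1. Among the compounds with values here, the only single-point step in the set is a 2.4-fold higher number from compound 1 to compound 2 (0.38 log units; beyond the scatter), removing a bromo from the shared core.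

Compound 4 `COc1cc(/C=N/Nc2nc(-c3ccc(Br)cc3)cs2)c(Br)c(Br)c1OC` differs from compound 1 as follows: bromo in place of hydrogen on an aromatic carbon. Within the data shown here, no measured step adds a halogen at this place; the step to compound 2 concerns a different position, and compound 3 carries fluorines on both rings without leaving the scatter of compound 1. No step beyond the scatter is therefore expected. Compound 4 is estimated at 22000 nM, range 9000 nM to 55000 nM. The expected step is a 1.2-fold lower number from compound 1 to compound 4 (0.08 log units; within the scatter).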

Compound 4, half-maximal inhibitory concentration: > 100000 nM
Compound 4 was reported as a limit (the forecaster's own chance of this, stated with the estimate: 10%); at least 4.5-fold (0.65 log units) between middle value and limit.
By their numbers in this assay, from the lowest: compounds 3 and 1 (each within the scatter of the next); then compound 2. At a limit, above all of these: compound 4.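

Within the data shown here, the phenyl to 4-bromophenyl change, on an aromatic carbon para to a large group, gives the first single-point step at this position in this assay: an at least 3.7-fold higher number from compound 1 to compound 4 (0.57 log units; beyond the scatter). Compound 4 gives > 100000 nM, which is a limit, so the step has no upper bound: the limit of > 100000 nM in this assay, at which 1 of the 4 values shown sits. Bromo does not behave alike at the two places, since its loss from the shared core also raises the number: a 2.4-fold higher number from compound 1 to compound 2 (0.38 log units; beyond the scatter).

As far as these compounds go, it remains open whether this rise belongs to bromo itself or to any group at this position. A methoxy, an amine or a carboxylic acid there would separate the two.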